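Swapping the Aryl Tail: Solubility Expected for Compound 4

The source may report more compounds than this note shows. Statements on the series, on what has been measured and on what is new or still open speak of the compounds shown alone.

Compound 1 `O=C(CN1CCN(c2cc3c(cc2F)c(=O)c(C(=O)O)cn3C2CC2)CC1)Nc1ccc(C(=O)/C=C/c2ccccc2)cc1` gives 2.53 ug/mL in a physicochemical assay for solubility, at pH 7.8; on this read-out higher numbers stand for higher solubility and lower numbers for lower solubility.
Compound 2 `O=C(CN1CCN(c2cc3c(cc2F)c(=O)c(C(=O)O)cn3C2CC2)CC1)Nc1ccc(C(=O)/C=C/c2ccccc2Cl)cc1` gives 2.12 ug/mL in this assay.
Compound 3 `COc1ccc(/C=C/C(=O)c2ccc(NC(=O)CN3CCN(c4cc5c(cc4F)c(=O)c(C(=O)O)cn5C4CC4)CC3)cc2)cc1` gives 2.42 ug/mL in this assay.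

The three measured compounds share one core and differ only in the substituted phenyl at the end of the chain. Compound 3 stands second highest of the three numbers, but its neighbours are very close: a 1.0-fold lower number from compound 1 to compound 3 (0.02 log units; within the scatter), and a 1.1-fold higher number from compound 2 to compound 3 (0.06 log units; within the scatter). Nothing here separates the three beyond the scatter.

Compound 4 `O=C(CN1CCN(c2cc3c(cc2F)c(=O)c(C(=O)O)cn3C2CC2)CC1)Nc1ccc(C(=O)/C=C/c2cccc([N+](=O)[O-])c2)cc1` is the next member of the series. Its difference from compound 3 is 3-nitrophenyl in place of 4-methoxyphenyl on a double-bonded chain carbon bound to a double-bonded chain carbon.

For the measured compounds named here, three measured steps bear on this change, all of them substitutions on that terminal phenyl: a 1.2-fold lower number from compound 1 to compound 2 (0.08 log units; within the scatter), a 1.0-fold lower number from compound 1 to compound 3 (0.02 log units; within the scatter), and a 1.1-fold higher number from compound 2 to compound 3 (0.06 log units; within the scatter). Each is within the scatter, so the measured data give no sign that changing the group on this phenyl moves solubility in either direction. The new group in compound 4 has not been tried before in this set, which leaves some uncertainty, but on the evidence available no step beyond the scatter is expected in this assay.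

Compound 4 is therefore estimated at 2.3 ug/mL, with a range of 1.1 ug/mL to 4.8 ug/mL. This estimate means an expected 1.1-fold lower number from compound 3 to compound 4 (0.02 log units; within the scatter).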

Compound 4, solubility: 27.4 ug/mL
Estimate against measurement, compound 4: 12-fold (1.08 log units) below; measured number outside the range, above it.
By their numbers in this assay, from the lowest: compounds 2, 3 and 1 (each within the scatter of the next); then compound 4.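

In this assay the terminal phenyl on the double-bonded chain carbon now proves able to move the read-out, as nitro in place of hydrogen gives an 11-fold higher number from compound 1 to compound 4 (1.03 log units; beyond the scatter) and stands apart from the chloro and methoxy changes, whose steps all stayed within the scatter. The gap holds against both substituted neighbours, with an 11-fold higher number from compound 3 to compound 4 (1.05 log units; beyond the scatter) and a 13-fold higher number from compound 2 to compound 4 (1.11 log units; beyond the scatter) both large and beyond the scatter, so compound 4 stands alone above compound 1, compound 2 and compound 3, which remain within the scatter of one another. Nothing measured here accounts for this large step, so the data show its size but not its origin.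

Compound 4 is the only compound shown with a nitro group, so it remains open whether the step belongs to that group in general or to the particular 3-nitrophenyl arrangement, and the same nitro group on another carbon of that phenyl would help to separate the two. On these data alone, it also remains open whether a nitrile or an amine on this phenyl would give a step of similar size or stay with compound 1, compound 2 and compound 3.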